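This account rests on a few compounds, and the source may have more. Where it says the series, first, only, none or still open, it means among the compounds named here.

Measured compounds in an ADME assay on Vero cells (Chlorocebus sabaeus) for cytotoxicity, read by MTT assay, with a stated time of 48 h; a higher number here means a weaker inhibitor, a lower number a stronger inhibitor:
Compound 1 `O=C(OC1CCC(CN2CCN(c3cc(=O)c4cc(C(F)(F)F)cc([N+](=O)[O-])c4s3)CC2)CC1)c1ccco1` gives > 64 ug/mL, a limit of the assay.
Compound 2 `O=C(OC1CCC(CN2CCN(c3cc(=O)c4cc(C(F)(F)F)cc([N+](=O)[O-])c4s3)CC2)CC1)c1ccc2ccccc2c1` gives > 64 ug/mL, likewise a limit.
Compound 3 `CC(=O)OC1CCC(CN2CCN(c3cc(=O)c4cc(C(F)(F)F)cc([N+](=O)[O-])c4s3)CC2)CC1` gives > 64 ug/mL, again a limit.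

Compound 1 thus stands only at a limit in this assay, with no number of its own. The two further values are limits as well, so the three compounds cannot be ordered against one another; the limit of > 64 ug/mL in this assay, at which 3 of the 3 values shown sit, summarises this.

The step to compound 4 `O=c1cc(N2CCN(CC3CCC(OS(=O)(=O)c4ccc5c(c4)CCO5)CC3)CC2)sc2c([N+](=O)[O-])cc(C(F)(F)F)cc12` changes the ester side of the molecule: a group of 12 heavy atoms (8 carbon, 3 oxygen, 1 sulfur; one five-membered non-aromatic ring with 1 hetero atom, one six-membered aromatic ring of carbon only) in place of a group of 7 heavy atoms (5 carbon, 2 oxygen; one five-membered aromatic ring with 1 hetero atom), on an oxygen on a saturated carbon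

The measured steps that touch the same place are a step that the two limits leave unreadable from compound 1 to compound 2, a step that the two limits leave unreadable from compound 1 to compound 3 and a step that the two limits leave unreadable from compound 2 to compound 3. None of them yields a readable size, since both ends of each sit at the limit. They do show that exchanging the group on that carbonyl carbon for a small methyl or for a larger naphthalen-2-yl left the value at the limit in every case. For compound 4 the change is larger in atom count, but nothing measured here points to a step beyond the scatter in this assay, in either direction.

Compound 4 is therefore expected to remain at or around the limit, with an estimated 90 ug/mL (range 45 ug/mL to 250 ug/mL), which corresponds to an expected step that the limit leaves unreadable from compound 1 to compound 4.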

Compound 4, half-maximal inhibitory concentration: > 64 ug/mL
Compound 4 gave a limit, no number; the forecaster's own chance of this, stated with the estimate: 80%; the middle value is on the limit's open side.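

No new step can be read in this assay: the steps from compound 1, compound 2 and compound 3 to compound 4 all join values at the assay limit, and the series rests on one summary: the limit of > 64 ug/mL in this assay, at which 4 of the 4 values shown sit.

The compounds shown leave open how far each of the four lies past that limit, and whether the group exchanged on the oxygen alters the value in this assay.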